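Fused core series: pyrazole replaces sulfonamide on the aromatic ring

A few compounds are considered here, and "the series" means these few. Any claim that something is new, unique, unknown or untested is made for them only; others in the source may bear on it.

Measured compounds:
compound 1, `COc1c(C)ccc2c1CCC2c1ncc[nH]1`: compound 1 gives 40%
compound 2, `CCCS(=O)(=O)Nc1cccc2c1CCC2c1ncc[nH]1`: compound 2 gives 54%
compound 3, `CCS(=O)(=O)Nc1cccc(Cc2c[nH]cn2)c1`: compound 3 gives 96%

All three values come from a functional assay on CHO cells for agonist activity at Alpha-1A adrenergic receptor (Homo sapiens), read by FLIPR and calcium flux; a lower number here means a smaller maximal response, a higher number a larger maximal response. Compound 2 sits second highest of the three numbers. Its nearest neighbour is compound 1, whose number lies lower by an amount beyond the scatter; the furthest is compound 3, whose number lies higher, again beyond the scatter. Within the data shown here, no pair among the three differs in one place only, so no single-point step can be read from the measured set.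

Compound 4, `Cn1cc(-c2cccc3c2CCC3c2ncc[nH]2)cn1`, is not yet measured. Relative to compound 2 the change is 1-methyl-1H-pyrazol-4-yl in place of (propylsulfonyl)amino on an aromatic carbon. The shared core is kept; only the group on that aromatic carbon is exchanged.

Among the measured compounds shown here, nothing among the measured compounds shows what this exchange does to the largest response in this assay. The step expected from compound 2 to compound 4, a number 4 percentage points lower from compound 2 to compound 4 (within the scatter), is therefore set small and could fall in either direction or stay within the scatter. For the measured compounds named here, for compound 4 the value in this assay is estimated at 50%, with a range from 25% to 80%, the width reflecting that no comparable step has been measured.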

Compound 4, largest response reached (Emax), in percent of the reference or control that the assay uses: 12%
Compound 4: the middle estimate sits 38 percentage points above what was measured, and the stated range ends above it.
By their numbers in this assay, from the lowest: compound 4; then compound 1; then compound 2; then compound 3.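

In this assay, among these compounds, the exchange of (propylsulfonyl)amino for 1-methyl-1H-pyrazol-4-yl gives a number 42 percentage points lower from compound 2 to compound 4 (beyond the scatter) and is the first single-point step available. With the shared core kept, the largest response is therefore sensitive to the group on this aromatic carbon, ortho to a fused ring, and the 1-methyl-1H-pyrazol-4-yl group does not preserve the response seen with (propylsulfonyl)amino. No supporting measurement is available to explain this loss of response.

Going by these compounds, whether the response depends on the whole (propylsulfonyl)amino group or only on part of it remains open, as this single exchange replaces the entire group at once. A plain amine, a carboxylic acid or a longer alkyl chain on the sulfonyl group at this carbon would each give a further single-point comparison with compound 2, while a pyrazol-4-yl group lacking the methyl would give one with compound 4.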